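Compound 4: dimethyl in place of difluoro

This account rests on a few compounds, and the source may have more. Where it says the series, first, only, none or still open, it means among the compounds named here.

Going by the values given here, in an in vitro ADME assay on microsomes from liver (Mus musculus) for pharmacokinetics (a lower number here means slower removal, a higher number faster removal of the compound), compound 3 (`O=C(NC1CC1)c1ccc(CN([C@@H]2CC(F)(F)CCNC2=O)S(=O)(=O)c2ccc(Cl)cc2)cc1`) gives 2.2 mL.min-1.g-1 as the lowest of three numbers so far. Compound 2 (`COc1ccc(CN([C@@H]2CC(F)(F)CCNC2=O)S(=O)(=O)c2ccc(Cl)cc2)cn1`) gives 72 mL.min-1.g-1 and compound 1 (`CC(C)(C)C1CCNC(=O)C(N(Cc2ccc(C(=O)NC3CC3)cc2)S(=O)(=O)c2ccc(Cl)cc2)C1`) gives 110 mL.min-1.g-1 in the same read-out. Compound 4 (`CC1(C)CCNC(=O)[C@H](N(Cc2ccc(C(=O)NC3CC3)cc2)S(=O)(=O)c2ccc(Cl)cc2)C1`) differs from compound 3 by one change (5,5-dimethyl-2-oxoazepan-3-yl in place of 5,5-difluoro-2-oxoazepan-3-yl on a sulfonamide nitrogen): 5,5-dimethyl-2-oxoazepan-3-yl in place of 5,5-difluoro-2-oxoazepan-3-yl on a sulfonamide nitrogen. Among the compounds with values here, the only measured step bearing on this is large (a 50-fold lower number from compound 1 to compound 3 (1.70 log units; beyond the scatter)) and also ends on the 5,5-difluoro-2-oxoazepan-3-yl group, there replacing 2-oxo-5-(tert-butyl)azepan-3-yl. Leaving that group is expected to give a higher number in a smaller step that is still expected to lie beyond the scatter (an 11-fold higher number from compound 3 to compound 4 (1.06 log units; beyond the scatter)). Compound 4 is estimated at 25 mL.min-1.g-1 with an expected range of 7 mL.min-1.g-1 to 80 mL.min-1.g-1 in this assay for now.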

Compound 4, intrinsic clearance in microsomes: 655 mL.min-1.g-1
Compound 4: middle estimate off by 26-fold (1.42 log units), on the low side, outside the stated range (above it).
By their numbers in this assay, from the lowest: compound 3; then compounds 2 and 1 (each within the scatter of the next); then compound 4.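

In this assay, the dimethyl and difluoro groups are equal in heavy atom count yet give a 300-fold higher number from compound 3 to compound 4 (2.47 log units; beyond the scatter), so the low number of compound 3 is specific to 5,5-difluoro-2-oxoazepan-3-yl and does not extend to this same-sized replacement. Losing the tert-butyl group does not by itself lower the number: 5,5-dimethyl-2-oxoazepan-3-yl in place of 2-oxo-5-(tert-butyl)azepan-3-yl gives a 6.0-fold higher number from compound 1 to compound 4 (0.77 log units; beyond the scatter). Nothing measured here accounts for the gap between these groups.

Where the unsubstituted 2-oxoazepan-3-yl or 5-fluoro-2-oxoazepan-3-yl group would fall between compound 3 and compound 4 remains open.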